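Swapping a Methyl for Trifluoromethylsulfanyl in Compound 2

This account rests on a few compounds, and the source may have more. Where it says the series, first, only, none or still open, it means among the compounds named here.

Of the compounds shown here, three sharing one core have been measured in an ADME assay for permeability, using PAMPA, at pH 7.4; a higher number here means that the compound crosses the layer faster, a lower number that the compound crosses the layer more slowly. Compound 2 `Cc1ccc(NC(=O)Nc2cc(C)nc3ccccc23)cc1` gives 669 10^-6 cm/s, the highest of the three numbers. Compound 1 `Cc1cc(NC(=O)Nc2ncccc2C)c2ccccc2n1` gives 369 10^-6 cm/s, and the step of a 1.8-fold higher number from compound 1 to compound 2 (0.26 log units; within the scatter) stays within the scatter. Compound 3 `Cc1cc(NC(=O)Nc2ccccc2N)c2ccccc2n1` gives 300 10^-6 cm/s; the step of a 2.2-fold lower number from compound 2 to compound 3 (0.35 log units; beyond the scatter) is modest but beyond the scatter, while the step of a 1.2-fold lower number from compound 1 to compound 3 (0.09 log units; within the scatter) is within it.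

The untested compound 4 `Cc1cc(NC(=O)Nc2ccc(SC(F)(F)F)cc2)c2ccccc2n1` differs from compound 2 at a single place: (trifluoromethyl)sulfanyl in place of methyl on an aromatic carbon. Every measured step exchanges the whole ring on the amide-type nitrogen, whereas this change keeps that ring and alters only the group on it. For the measured compounds named here, no measured step therefore bears directly on it, and the nearest comparisons, a 1.8-fold higher number from compound 1 to compound 2 (0.26 log units; within the scatter) and a 2.2-fold lower number from compound 2 to compound 3 (0.35 log units; beyond the scatter), were themselves small. In this assay the step of a 1.1-fold lower number from compound 2 to compound 4 (0.05 log units; within the scatter) is the expected outcome, within the scatter. Compound 4 is estimated at 600 10^-6 cm/s, with a range from 300 10^-6 cm/s to 1100 10^-6 cm/s.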

Compound 4, apparent permeability: 206 10^-6 cm/s
Compound 4: middle estimate off by 2.9-fold (0.46 log units), on the high side; the whole stated range lies above it.
By their numbers in this assay, from the lowest: compounds 4, 3, 1 and 2 (each within the scatter of the next, the first and the last beyond it).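

In this assay, for the compounds shown here, this is the first step that keeps the ring on the amide-type nitrogen and alters only the group on it, and the exchange of methyl for (trifluoromethyl)sulfanyl gives a 3.2-fold lower number from compound 2 to compound 4 (0.51 log units; beyond the scatter). A group para to a large group can therefore move the number beyond the scatter by itself, and the change is of the same modest size as a whole-ring exchange, a 2.2-fold lower number from compound 2 to compound 3 (0.35 log units; beyond the scatter). Nothing shown here explains this drop, so its cause remains unknown.

This single pair cannot separate the contribution of the sulfur from that of the fluorines or of the larger group as a whole. Going by these compounds, how the number responds to a plain trifluoromethyl, a methoxy group or a chlorine atom at this place remains open.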